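Moving the methoxy group on the aryl ring of compound 2

This account rests on a few compounds, and the source may have more. Where it says the series, first, only, none or still open, it means among the compounds named here.

The shared core of compound 1 `COc1ccccc1Oc1c(N)nc(-c2ccccc2)nc1Cl` carries a phenyl ring that is varied across this small set. In a toxicity assay on HaCaT cells (Homo sapiens) for cytotoxicity, read by CCK-8 assay, with a stated time of 24 h (a higher number here means that more compound is tolerated, a lower number that less compound is tolerated), compound 1 gives "not active" (no number reported), so no number is available for it. Compound 2 `COc1ccccc1Oc1c(N)nc(-c2cccc(C)c2)nc1Cl` carries a 3-methylphenyl group and gives 11200 nM in this assay; compound 3 `COc1cccc(-c2nc(N)c(Oc3ccccc3OC)c(Cl)n2)c1` carries a 3-methoxyphenyl group and gives 14000 nM, and the two values lie within the scatter of each other, so neither can be placed above the other. For the measured compounds named here, the single measured step, a 1.3-fold higher number from compound 2 to compound 3 (0.10 log units; within the scatter), is the only change on this ring with a number attached. Compound 4 `COc1ccc(-c2nc(N)c(Oc3ccccc3OC)c(Cl)n2)cc1` differs from compound 2 by 4-methoxyphenyl in place of 3-methylphenyl on an aromatic carbon. Going by the values given here, the methoxy group now sits in a different position on the aryl ring than in compound 3, a change for which no measured step exists, so the expectation rests on compound 2 and compound 3 alone. Given that the move from compound 2 to compound 3 stayed within the scatter, compound 4 is expected to show a step of a 1.2-fold higher number from compound 2 to compound 4 (0.06 log units; within the scatter), no larger than the scatter. Compound 4 is therefore estimated at 13000 nM, with a range from 6000 nM to 28000 nM.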

Compound 4, half-maximal cytotoxic concentration: 8200 nM
Compound 4: the middle estimate sits 1.6-fold (0.20 log units) above what was measured; low and high end bracket the measured number.
By their numbers in this assay, from the lowest: compounds 4, 2 and 3 (each within the scatter of the next).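

In this assay, for the compounds shown here, 4-methoxyphenyl in place of 3-methoxyphenyl gives a 1.7-fold lower number from compound 3 to compound 4 (0.23 log units; within the scatter), so this is the first reading of the methoxy group at a second position on the aryl ring, and the printed step does not separate the two positions. 4-methoxyphenyl in place of 3-methylphenyl gives a 1.4-fold lower number from compound 2 to compound 4 (0.14 log units; within the scatter), so among compound 2, compound 3 and compound 4, neither the group nor its position on this ring separates the numbers. Nothing in the data available accounts for these numbers.

With compound 1 at "not active" (no number reported), the unsubstituted phenyl ring cannot be set against the three substituted rings by number. As far as these compounds go, whether an amine or a carboxylic acid on this aryl ring would give a step beyond the scatter remains open.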